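Compound 3 to compound 4: a swap at the limit

A few compounds are considered here, and "the series" means these few. Any claim that something is new, unique, unknown or untested is made for them only; others in the source may bear on it.

In an ADME assay on HepG2 cells (Homo sapiens) for inhibition, with a stated time of 48 h (on this read-out lower numbers stand for an effect already at smaller amounts and higher numbers for an effect only at larger amounts of compound), compound 3 `CC(C(=O)N1CCc2ccccc21)N1CCN(S(=O)(=O)c2ccc(C(C)(C)C)cc2)CC1` gives > 40000 nM, which is a limit and not a number. Compound 1 `CC(C(=O)N1C[C@H]2CCC[C@H]2C1)N1CCN(S(=O)(=O)c2ccc(C(C)(C)C)cc2)CC1` gives > 40000 nM, also a limit. Compound 2 `CC(C(=O)N1CCC2(CC1)CC2)N1CCN(S(=O)(=O)c2ccc(C(C)(C)C)cc2)CC1` gives > 40000 nM, again a limit. Compound 3 therefore has no readable rank among the three: the limit of > 40000 nM in this assay, at which 3 of the 3 values shown sit.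

The change under review leads to compound 4 `CC(C(=O)N1Cc2ccccc2C1)N1CCN(S(=O)(=O)c2ccc(C(C)(C)C)cc2)CC1`: a group of 9 heavy atoms (8 carbon, 1 nitrogen; one five-membered non-aromatic ring with 1 hetero atom, one six-membered aromatic ring of carbon only) in place of a group of 9 heavy atoms (8 carbon, 1 nitrogen; one five-membered non-aromatic ring with 1 hetero atom, one six-membered aromatic ring of carbon only), on a carbonyl carbon. The two have the same atoms, joined differently. The 2,3-dihydro-1H-indol-1-yl group leaves and a group with no common name enters, on a carbonyl carbon.

The measured steps at that carbonyl carbon bear on this change. They are a step that the two limits leave unreadable from compound 1 to compound 2, then a step that the two limits leave unreadable from compound 1 to compound 3, and finally a step that the two limits leave unreadable from compound 2 to compound 3. None of them has a readable size, so they offer no measured effect to carry over. Compound 4 is expected to stay at the same limit because of the limit of > 40000 nM in this assay, at which 3 of the 3 values shown sit. No step beyond the usual scatter is expected in this assay, and the expected step is a number no higher from compound 3 to compound 4 (the limit leaves the size open). The estimate for compound 4 is 40000 nM, with an expected range from 20000 nM to 80000 nM.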

Compound 4, half-maximal effective concentration: > 40000 nM
Compound 4 was reported as a limit; the forecaster's own chance of this, stated with the estimate: 85%; the middle value sits exactly at the limit.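

In this assay compound 4 gives > 40000 nM, which is a limit and not a number. Among the compounds shown here, no step from compound 1, compound 2 or compound 3 to compound 4 can be read, because all four compounds share one limit: the limit of > 40000 nM in this assay, at which 4 of the 4 values shown sit.

The compounds shown leave open whether any change on the carbonyl carbon shifts this read-out at all.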